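Swapping the pendant aryl ring for pyridin-4-yl

The source may report more compounds than this note shows. Statements on the series, on what has been measured and on what is new or still open speak of the compounds shown alone.

Of the compounds shown here, three sharing one core have been measured in a functional assay on K562 cells (Homo sapiens) for antiproliferative activity, read by MTT assay, with a stated time of 48 h; a lower number here means a stronger inhibitor, a higher number a weaker inhibitor. Compound 1 `COc1ccc(CN2C(=O)C(=O)c3cc(-c4cc(OC)cc(OC)c4)ccc32)cc1` gives 510 nM, compound 2 `COc1ccc(CN2C(=O)C(=O)c3cc(-c4ccc(F)cc4)ccc32)cc1` gives 240 nM, and compound 3 `COc1ccc(CN2C(=O)C(=O)c3cc(-c4ccc(F)c(Cl)c4)ccc32)cc1` gives 380 nM. Compound 3 stands second of the three, within the scatter of both neighbours: the step of a 1.3-fold lower number from compound 1 to compound 3 (0.13 log units; within the scatter) and the step of a 1.6-fold higher number from compound 2 to compound 3 (0.20 log units; within the scatter) are each too small to read as a change, while only a 2.1-fold lower number from compound 1 to compound 2 (0.33 log units; beyond the scatter) reaches beyond it.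

Compound 4 `COc1ccc(CN2C(=O)C(=O)c3cc(-c4ccncc4)ccc32)cc1` differs from compound 3 in one place: pyridin-4-yl in place of 3-chloro-4-fluorophenyl on an aromatic carbon. For the measured compounds named here, the steps that bear on this are the earlier swaps of the pendant ring, all of which moved the number in this assay by a modest amount at most. None of them introduced a ring with a hetero atom, so the effect of pyridin-4-yl itself is not covered by any measured pair.

On that basis compound 4 is expected to fall near compound 3, with a step of a 1.1-fold higher number from compound 3 to compound 4 (0.02 log units; within the scatter) at most. The estimate for compound 4 in this assay is 400 nM, in the range 150 nM to 1100 nM.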

Compound 4, half-maximal inhibitory concentration: 40 nM
Estimate against measurement, compound 4: 10-fold (1.00 log units) above, and the stated range ends above it.
By their numbers in this assay, from the lowest: compound 4; then compounds 2, 3 and 1 (each within the scatter of the next, the first and the last beyond it).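

In this assay the pendant ring at this position matters far more than the rings of carbon only had suggested: pyridin-4-yl gives a 9.5-fold lower number from compound 3 to compound 4 (0.98 log units; beyond the scatter) and also a 6.0-fold lower number from compound 2 to compound 4 (0.78 log units; beyond the scatter) and also a 13-fold lower number from compound 1 to compound 4 (1.11 log units; beyond the scatter) against the three earlier rings. Among those earlier rings, the only step beyond the scatter was a 2.1-fold lower number from compound 1 to compound 2 (0.33 log units; beyond the scatter) and it is smaller than any of these, so compound 4 stands apart from all three. Nothing measured here accounts for the step. The compounds shown leave open whether the step belongs to the ring nitrogen of pyridin-4-yl or to the absence of substituents on the ring, a question that plain phenyl, pyridin-3-yl or pyrimidin-5-yl could help to settle. From the compounds shown here alone, it is equally open whether the lower number would persist in a pyridin-4-yl ring carrying an amine or a methyl group.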